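Swapping a hydroxy for an amino on a benzophenone

The source may report more compounds than this note shows. Statements on the series, on what has been measured and on what is new or still open speak of the compounds shown alone.

Three benzophenone-type compounds stand alongside one another here. Compound 1 `COc1ccc(C(=O)c2ccc(OC)c(O)c2OC)cc1` carries a hydroxy on one ring; in a functional assay on MCF7 cells (Homo sapiens) for cytotoxicity, read by sulforhodamine B assay, with a stated time of 48 h (a lower number here means a stronger inhibitor of growth, a higher number a weaker inhibitor of growth), compound 1 shows "not determined" (no result reported), so no number is available for it. Compound 2 `COc1ccc(C(=O)c2cc(OC)c(OC)c(OC)c2)c(OC)c1O` holds the lowest number of the two that were reported, giving 26.4 nM in this assay. Compound 3 `COc1cc(C(=O)c2ccc3c(c2)oc(=O)n3S(C)(=O)=O)cc(OC)c1OC` is far weaker, with 4430 nM in this assay, a gap that lies well beyond the scatter of this kind of measurement.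

The next compound, compound 4 `COc1ccc(C(=O)c2cc(OC)c(OC)c(OC)c2)c(OC)c1N`, differs from compound 2 in a single place: amino in place of hydroxy on an aromatic carbon. Going by the values given here, no pair of measured compounds shows this exact exchange, so the expectation for compound 4 rests only on the strength of compound 2 and on the modest nature of the change. The step from compound 2 is expected to be small, if anything a slight loss, within or near the scatter: a 1.5-fold higher number from compound 2 to compound 4 (0.18 log units; within the scatter). In this assay compound 4 is therefore expected to give about 40 nM, most likely between 10 nM and 200 nM.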

Compound 4, concentration for 50% growth inhibition: 10.6 nM
Compound 4: the middle estimate sits 3.8-fold (0.58 log units) above what was measured; the range from low to high includes it.
By their numbers in this assay, from the lowest: compound 4; then compound 2; then compound 3.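

In this assay, amino in place of hydroxy gives a 2.5-fold lower number from compound 2 to compound 4 (0.40 log units; beyond the scatter), so a low number at this position, ortho to two methoxy groups, does not depend on the hydroxy, and the amino serves at least as well. Going by these compounds alone, the earlier compounds held no pair differing in one place, so this step is the first direct reading of any single change on the shared core. Nothing available explains why the amino gives the lower number.

Going by these compounds, whether a methylamino group, an acetamide or a fluorine at this same position would hold or lower the number remains open. A single step on a single core also leaves open whether the same exchange would act in the same direction on any other core.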